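The source may hold more compounds than are shown below. What is called first, only, known or untested is meant among the compounds shown, and "the series" means these compounds.

Measured compounds:
Compound 1 `COc1cc2c(Oc3ccc(NC(=O)c4cn(-c5ccccc5C)nn4)cc3F)ccnc2cc1OCCCN1CCCC1` gives 900 nM in a functional assay on A549 cells (Homo sapiens) for cytotoxicity, read by MTT assay, with a stated time of 72 h; a higher number here means a weaker inhibitor, a lower number a stronger inhibitor.
Compound 2 `COc1cc2c(Oc3ccc(NC(=O)c4cn(-c5ccccc5C)nn4)cc3F)ccnc2cc1OCCCN1CCCCC1` gives 3230 nM in this assay.

Within the data shown here, compound 2 stands at the highest of the two numbers in this assay; its nearest neighbour is compound 1, and the single measured step is a 3.6-fold higher number from compound 1 to compound 2 (0.55 log units; beyond the scatter). Compound 3 `COc1cc2c(Oc3ccc(NC(=O)c4cn(-c5ccc(F)c(F)c5)nn4)cc3F)ccnc2cc1OCCCN1CCCCC1` differs from compound 2 in another part of the molecule: 3,4-difluorophenyl in place of 2-methylphenyl on an aromatic nitrogen. Among the measured compounds shown here, no measured step touches this aromatic nitrogen, since the one step known concerns the saturated chain on the other side of the shared core. Nothing measured therefore bears on the change from compound 2 to compound 3, and the expectation rests on compound 2 alone, with a wide range. The step is estimated as a 1.1-fold lower number from compound 2 to compound 3 (0.03 log units; within the scatter), that is no change beyond the scatter in this assay. Compound 3 is expected to give about 3000 nM in this assay, within a range from 700 nM to 13000 nM.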

Compound 3, half-maximal inhibitory concentration: 220 nM
Beside the measured number, compound 3's estimate is 14-fold (1.13 log units) above it; the whole stated range lies above it.
By their numbers in this assay, from the lowest: compound 3; then compound 1; then compound 2.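

In this assay the group on the aromatic nitrogen of the five-membered ring proves to be a strong handle: 3,4-difluorophenyl in place of 2-methylphenyl gives a 15-fold lower number from compound 2 to compound 3 (1.17 log units; beyond the scatter). Among these compounds, until this result only the saturated chain had been seen to shift the number, and that step, a 3.6-fold higher number from compound 1 to compound 2 (0.55 log units; beyond the scatter), was modest, whereas this one is large and occurs with the piperidin-1-yl chain held fixed. No available evidence accounts for the size of this step.

The compounds shown do not separate the departure of the methyl group from the arrival of the two fluorines, so a plain phenyl or a 4-fluorophenyl group on this nitrogen remains an open case. Also open, from the compounds shown here alone, is how 3,4-difluorophenyl would behave alongside the pyrrolidin-1-yl chain of compound 1.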